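The source may hold more compounds than are shown below. What is called first, only, known or untested is meant among the compounds shown, and "the series" means these compounds.

Two compounds have so far been measured in an assay on cells for antagonist activity at transient receptor potential cation channel subfamily V member 1 (Homo sapiens), read by FLIPR and calcium flux, with a stated time of 6 min; on this read-out higher numbers stand for weaker inhibition and lower numbers for stronger inhibition:

Compound 1 `CC(C(=O)NCc1ccc(C(C)(C)C)nc1N1CCC(Cc2ccccc2)CC1)c1ccc(NS(C)(=O)=O)c(F)c1` gives 0.3 nM.
Compound 2 `CC(C)COc1nc(C(C)(C)C)ccc1CNC(=O)C(C)c1ccc(NS(C)(=O)=O)c(F)c1` gives 0.6 nM.

Compound 2 stands at the highest of the two numbers shown, but its only neighbour, compound 1, differs from it by an amount that lies within the usual scatter of repeated measurements of this kind, so on these data the two compounds cannot be told apart. Among the measured compounds shown here, they share the same core yet differ in more than one place, so no single-change step between measured compounds is available to guide a prediction.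

Compound 3 `CC(C(=O)NCc1ccc(C(C)(C)C)nc1SCCCN(C)C)c1ccc(NS(C)(=O)=O)c(F)c1` has not yet been measured. It is derived from compound 2 by one change: (3-(dimethylamino)propyl)sulfanyl in place of isobutoxy on an aromatic carbon. For the measured compounds named here, with no measured step of this kind to lean on, the expectation in this assay is a modest shift towards a higher number, perhaps just beyond the scatter, although a result within it would not be surprising. Compound 3 is therefore expected to give about 3 nM, with a plausible range from 0.6 nM to 15 nM. This estimate corresponds to a step of a 5.0-fold higher number from compound 2 to compound 3 (0.70 log units; beyond the scatter).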

Compound 3, inhibition constant: 51.8 nM
Estimate against measurement, compound 3: 17-fold (1.24 log units) below; the whole stated range lies below it.
By their numbers in this assay, from the lowest: compounds 1 and 2 (each within the scatter of the next); then compound 3.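

This step is the first single-change comparison among the compounds shown, and it shows that the group on this aromatic carbon, next to the ring nitrogen, can strongly affect the result. In this assay, replacing isobutoxy with (3-(dimethylamino)propyl)sulfanyl gives an 86-fold higher number from compound 2 to compound 3 (1.94 log units; beyond the scatter), a large step towards weaker inhibition. The swap changes several things at once, putting sulfur where oxygen stood, lengthening the group and adding a dimethylamino end, and no measurement here explains the drop or assigns it to any one of these features.

The compounds shown leave open which part of the new group accounts for the step: a 3-(dimethylamino)propoxy group would keep the amine with an oxygen link, while an isobutylsulfanyl group would keep the sulfur link without the amine. As far as these compounds go, it also remains open how the chain length and the end group each matter, which a shorter 2-(dimethylamino)ethylsulfanyl chain or a chain ending in a carboxylic acid could help to test.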